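Aryl amide variation on the cyanoquinoline series

The source may report more compounds than this note shows. Statements on the series, on what has been measured and on what is new or still open speak of the compounds shown alone.

Measured so far:
- compound 1, `Cc1cc(C)c2cc(C#N)c(NCCNC(=O)c3ccccc3)nc2c1`: "not active" (no number reported)
- compound 2, `Cc1cc(C)c2cc(C#N)c(NCCNC(=O)c3cnccn3)nc2c1`: 6700 nM
- compound 3, `COc1ccc(C(=O)NCCCNc2nc3cc(C)cc(C)c3cc2C#N)cc1`: 4300 nM

In an in vitro assay on FRT cells with Cystic fibrosis transmembrane conductance regulator variant F508del (Homo sapiens) as the target, read by fluorescence, with a stated time of 24 h, at 37 degrees C, in the presence of a further agent that is not named here (a lower number here means that less compound is needed, a higher number that more compound is needed for the effect), compound 3 gives the lower of the two reported numbers, and compound 2 sits within the scatter of it, so no order can be drawn from that pair. Compound 1 gives no number at all in this assay.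

Compound 4, `Cc1cc(C)c2cc(C#N)c(NCCCNC(=O)c3ccncc3)nc2c1`, has not been measured. It differs from compound 3 by pyridin-4-yl in place of 4-methoxyphenyl on a carbonyl carbon. Among the measured compounds shown here, no measured pair isolates this change; compound 1 and compound 2 show an aza-aromatic ring giving a number where the carbocyclic ring gives none, but they carry a different linker.

Compound 4 is expected to stay close to compound 3, with the step of a 1.1-fold lower number from compound 3 to compound 4 (0.03 log units; within the scatter) estimated as no more than the scatter. The estimate for compound 4 is 4000 nM, range 1500 nM to 12000 nM.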

Compound 4, half-maximal effective concentration: 8200 nM
Compound 4: the middle estimate sits 2.1-fold (0.31 log units) below what was measured; the measured number falls inside the stated range.
By their numbers in this assay, from the lowest: compounds 3, 2 and 4 (each within the scatter of the next).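

With the linker of compounds 3 and 4 held constant, pyridin-4-yl in place of 4-methoxyphenyl on a carbonyl carbon gives a 1.9-fold higher number from compound 3 to compound 4 (0.28 log units; within the scatter) in this assay. Among the compounds shown here, this is the first step that isolates the aryl ring, and it shows that both a carbon-only ring and a ring with 1 hetero atom give numbers on this linker. Nothing available bears on the reason for this result.

Open, as far as these compounds go, is whether the unsubstituted phenyl ring of compound 1 gives a number on this linker. Also open, from the compounds shown here alone, is how a saturated piperidin-4-yl ring or a carboxylic acid on the aromatic ring would read.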